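The compounds below may be only part of what the source reports. "The series", "measured", "known", "first", "only" and "open" are said of these compounds alone.

Measured in a functional assay on MCF7 cells (Homo sapiens) for cytotoxicity, read by MTT assay, with a stated time of 72 h; on this read-out lower numbers stand for stronger inhibition and higher numbers for weaker inhibition:
- compound 1 `Cc1ccc2[nH]c(-c3ccc[nH]3)c(C3CC(=O)NC3=O)c2c1`: 29000 nM
- compound 2 `c1ccc2[nH]c(-n3cccn3)cc2c1`: the value is a limit of the assay, > 100000 nM
- compound 3 `O=C1NC(=O)c2c1c1c3cc(O)ccc3[nH]c1c1cccn21`: again only a limit of the assay is reported, > 100000 nM

Compound 1 thus stands alone with a number; the other two sit at the limit of > 100000 nM in this assay, at which 2 of the 3 values shown sit. Within the data shown here, no step between measured compounds is available, so the scale of a single change is not known from this set.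

Compound 4 `O=C1CC(c2c(-c3ccc[nH]3)[nH]c3ccccc23)C(=O)N1` differs from compound 1 in one place: hydrogen in place of methyl on an aromatic carbon. A step of this kind in this assay is expected to stay within the scatter, with no clear direction. Compound 4 is therefore estimated at 35000 nM, range 12000 nM to 100000 nM, the expected step being a 1.2-fold higher number from compound 1 to compound 4 (0.08 log units; within the scatter).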

Compound 4, half-maximal inhibitory concentration: 35000 nM
Compound 4: middle estimate and measured number agree at the digits printed, and the stated range covers the measured number.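

In this assay, hydrogen in place of methyl on this aromatic carbon gives a 1.2-fold higher number from compound 1 to compound 4 (0.08 log units; within the scatter). Among these compounds, this is the first single-place step in the set, and it gives a first scale for one change: at this position, methyl and hydrogen cannot be told apart in this assay. Going by these compounds, whether a methoxy group, chlorine or an amine at the same place would move the number stays open, as does any change elsewhere on the shared core. Compound 2 and compound 3 give only a limit of the assay, not a number: the limit of > 100000 nM in this assay, at which 2 of the 4 values shown sit.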